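The source may report more compounds than this note shows. Statements on the series, on what has been measured and on what is new or still open speak of the compounds shown alone.

In a functional assay on HeLa cells (Homo sapiens) for cytotoxicity, read by MTT assay, with a stated time of 48 h (on this read-out lower numbers stand for stronger inhibition and higher numbers for weaker inhibition), compound 1 `COc1cc([C@@H]2C[C@]2(CO)C(=O)NCc2ccc(C)cc2)cc(OC)c1OC` gives 17400 nM. Among the measured compounds shown here, the only other measured compound, compound 2 `CCOC(=O)[C@]1(C(=O)NCc2ccc(C)cc2)C[C@H]1c1cc(OC)c(OC)c(OC)c1`, gives 28500 nM, so the two stand level within the scatter and neither can be ranked over the other. Compound 3 `COc1cc([C@H]2C[C@]2(CO)C(=O)NCc2ccc(C)cc2)cc(OC)c1OC` keeps every atom and bond of compound 1: the two compounds have the same atoms and bonds and differ only in configuration as drawn: 1 of 2 stereo elements differ; a stereocentre at a saturated ring carbon is drawn S in compound 1 and R in compound 3. Put plainly, a stereocentre at a saturated ring carbon is drawn S in compound 1 and R in compound 3. For the measured compounds named here, the one measured step, a 1.6-fold higher number from compound 1 to compound 2 (0.21 log units; within the scatter), concerns a change of group, not of configuration, so it bears on this change only weakly. Going by the values given here, no measured pair here differs in configuration alone, and the data favour no direction. The range must therefore stay wide, but no shift beyond the scatter is expected in this assay. The expected step is a 1.1-fold higher number from compound 1 to compound 3 (0.06 log units; within the scatter). Compound 3 is estimated at 20000 nM, with an expected range from 7000 nM to 55000 nM.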

Compound 3, half-maximal inhibitory concentration: 57800 nM
The estimate for compound 3 lay 2.9-fold (0.46 log units) below the measured number; the measured number lies above the stated range.
By their numbers in this assay, from the lowest: compounds 1 and 2 (each within the scatter of the next); then compound 3.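

In this assay, the step of a 3.3-fold higher number from compound 1 to compound 3 (0.52 log units; beyond the scatter) shows that the drawn configuration at this saturated ring carbon can move the number on its own, with compound 3 the weaker of the two. The only earlier step, a 1.6-fold higher number from compound 1 to compound 2 (0.21 log units; within the scatter), changed a group and left the two numbers level, so this modest step is the first shown to lie beyond the scatter. It can be laid on this one stereocentre, because no atom or bond changes and the other stereo element stays as drawn, as the structures show: the fact that compounds 1 and 3 differ only in the configuration as drawn.

Open, on these data alone, is whether the same inversion gives a similar step with ethoxycarbonyl in place of hydroxymethyl, and what inverting the second stereocentre does. Also open, as far as these compounds go, is how a carboxylic acid or an amine in place of hydroxymethyl would read.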